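Swapping an amino group for methylseleno on a chalcone core

The source may report more compounds than this note shows. Statements on the series, on what has been measured and on what is new or still open speak of the compounds shown alone.

Of the compounds shown here, two have been measured in a functional assay on HCT-8 cells (Homo sapiens) for antiproliferative activity, read by MTT assay, with a stated time of 48 h; a lower number here means a stronger inhibitor, a higher number a weaker inhibitor. Compound 1, with the structure `COc1cc(C(=O)/C=C/c2cn(C)c3ccccc23)cc(SC)c1OC`, gives 210 nM. Compound 2, with the structure `COc1ccc2c(/C=C/C(=O)c3cc(N)c(OC)c(OC)c3)c[nH]c2c1`, gives 368 nM. These two numbers lie within the usual scatter of repeated measurements of each other, so no order between them can be read from the data.

The next compound, compound 3, has the structure `COc1ccc2c(/C=C/C(=O)c3cc(OC)c(OC)c([Se]C)c3)c[nH]c2c1`. It differs from compound 2 in one place on the aromatic six-membered carbon ring that carries the carbonyl side: a group of 2 heavy atoms (1 carbon, 1 selenium; no ring) in place of one nitrogen atom, on an aromatic carbon. The group that enters brings no hydrogen-bond donor or acceptor, whereas the amino group that leaves had one of each.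

Among the measured compounds shown here, no measured pair shows exactly this kind of exchange. Compound 1, which carries a different two-atom group at a related position of its own core, gives a number in this assay close to that of compound 2. On that basis, a modest move toward a lower number is expected for compound 3, of a size near the edge of the scatter. The estimate for compound 3 in this assay is 160 nM, with a range from 50 nM to 550 nM, which is an expected step of a 2.3-fold lower number from compound 2 to compound 3 (0.36 log units; beyond the scatter).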

Compound 3, half-maximal inhibitory concentration: 78 nM
Compound 3: middle estimate off by 2.1-fold (0.31 log units), on the high side, and the stated range covers the measured number.
By their numbers in this assay, from the lowest: compound 3; then compounds 1 and 2 (each within the scatter of the next).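

In this assay, among the compounds shown here, putting methylseleno in place of the amino group on this aromatic carbon, ortho to a methoxy group, gives a 4.7-fold lower number from compound 2 to compound 3 (0.67 log units; beyond the scatter) and is the first step in this set that can be read beyond the scatter. It shows that the number at this position responds to the exchange, and that the hydrogen-bond donor and acceptor of the amino group are not required for a low number in this pair, since the entering group has neither. Nothing measured here accounts for the step, so which part of the exchange matters stays unknown.

From the compounds shown here alone, a single step cannot separate the effect of losing the amino group from the effect of gaining selenium, so it remains open how a methylthio group, a hydroxyl group or a longer chain such as ethylseleno would read at this carbon of the shared core. Going by these compounds, it also remains open whether the same exchange would move the number in the same direction on a different core.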